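Swapping a methoxy for a methyl on a thiophene-fused core

The source may report more compounds than this note shows. Statements on the series, on what has been measured and on what is new or still open speak of the compounds shown alone.

Of the compounds shown here, two sharing one core have been measured. Compound 1, `COC(=O)c1sc2cc(C)ccc2c1Nc1cc(OC)c(OC)c(OC)c1`, was tested in a functional assay on HeLa cells (Homo sapiens) for cytotoxicity, read by MTT assay, with a stated time of 72 h (on this read-out higher numbers stand for weaker inhibition and lower numbers for stronger inhibition), where compound 1 gives 0.31 nM. Compound 2, `CCOC(=O)c1sc2cc(OC)ccc2c1Nc1cc(OC)c(OC)c(OC)c1`, is the second; in this assay compound 2 gives 0.56 nM. Compound 2 has the higher of the two numbers, but the gap to compound 1 lies within the scatter, so the two cannot be told apart on these data.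

Compound 3, `CCOC(=O)c1sc2cc(C)ccc2c1Nc1cc(OC)c(OC)c(OC)c1`, has not yet been measured. It differs from compound 2 in one place: methyl in place of methoxy on an aromatic carbon. Among the measured compounds shown here, no step between measured compounds isolates this particular change, so nothing here shows what it does on its own; only the fact that compound 1 and compound 2 sit so close gives a sense of how little the numbers move across this small series.

The step of a 1.4-fold lower number from compound 2 to compound 3 (0.15 log units; within the scatter) is expected to stay within the scatter. Compound 3 is therefore estimated to give 0.4 nM, with a range from 0.15 nM to 1.2 nM.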

Compound 3, half-maximal inhibitory concentration: 0.38 nM
The estimate for compound 3 lay 1.1-fold (0.02 log units) above the measured number; low and high end bracket the measured number.
By their numbers in this assay, from the lowest: compounds 1, 3 and 2 (each within the scatter of the next).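

In this assay, methyl in place of methoxy on an aromatic carbon now has a step of its own (a 1.5-fold lower number from compound 2 to compound 3 (0.17 log units; within the scatter)), so on these data the two groups cannot be told apart at this place on the shared core. This holds even though the methoxy has one more heavy atom and one hydrogen-bond acceptor, while the methyl has none. Compound 3 also links compound 1 to the series through a single change, from methyl ester to ethyl ester (a 1.2-fold higher number from compound 1 to compound 3 (0.09 log units; within the scatter)), and that change cannot be told apart from no change at all, so the two ester groups are equally indistinguishable here. No measurement is available that could explain these results.

Going by these compounds, what an amine or a carboxylic acid would do on this aromatic carbon remains open, since both of the groups compared here are small and uncharged. On these data alone, it is equally open whether a longer chain on the ester would leave the number within the scatter or move it beyond.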